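Swapping chloro for cyano on a sulfonyl aryl group

The compounds below may be only part of what the source reports. "The series", "measured", "known", "first", "only" and "open" are said of these compounds alone.

compound 1 `N#Cc1ccc(S(=O)(=O)N2C/C(=C\c3ccncc3)C(=O)/C(=C/c3ccccc3F)C2)cc1`: 4500 nM
compound 2 `O=C1/C(=C/c2ccncc2)CN(S(=O)(=O)c2ccccc2)C/C1=C\c1ccccc1C(F)(F)F`: 7020 nM
compound 3 `O=C1/C(=C/c2ccncc2)CN(S(=O)(=O)c2ccc(Cl)cc2)C/C1=C\c1ccccc1C(F)(F)F`: 7190 nM

In a functional assay on HepG2 cells (Homo sapiens) for cytotoxicity, read by MTT assay, with a stated time of 24 h (on this read-out lower numbers stand for stronger inhibition and higher numbers for weaker inhibition), compound 3 gives 7190 nM, which lies within the scatter of both other measured compounds, so the numbers set no order among them. Compound 4 `N#Cc1ccc(S(=O)(=O)N2C/C(=C\c3ccncc3)C(=O)/C(=C/c3ccccc3C(F)(F)F)C2)cc1` differs from compound 3 in one place: cyano in place of chloro on an aromatic carbon.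

Two pieces of evidence bear on this swap. The closest is a change in the same group, a 1.0-fold higher number from compound 2 to compound 3 (0.01 log units; within the scatter), and it moved the number by no more than the scatter. The second is compound 1, which already carries the 4-cyanophenyl group but differs from compound 4 on another ring. Compound 1 gives 4500 nM, and that too lies within the scatter of compound 3.

No step beyond the scatter is therefore expected in this assay. The expected step is a 1.2-fold lower number from compound 3 to compound 4 (0.08 log units; within the scatter). Compound 4 is estimated at 6000 nM, with an expected range of 3500 nM to 10000 nM.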

Compound 4, half-maximal inhibitory concentration: 5920 nM
The estimate for compound 4 lay 1.0-fold (0.01 log units) above the measured number, within the range that was stated.
By their numbers in this assay, from the lowest: compounds 1, 4, 2 and 3 (each within the scatter of the next).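

In this assay, for the compounds shown here, the result gives the first direct look at cyano at this position, and a 1.2-fold lower number from compound 3 to compound 4 (0.08 log units; within the scatter) shows that it reads no differently from chloro. Setting it against an unsubstituted ring gives a 1.2-fold lower number from compound 2 to compound 4 (0.07 log units; within the scatter) and leads to the same reading, so hydrogen, chloro and cyano on this aromatic carbon cannot be told apart in these compounds. With the 4-cyanophenyl group held constant, trifluoromethyl in place of fluoro on the other aromatic ring gives a 1.3-fold higher number from compound 1 to compound 4 (0.12 log units; within the scatter) and so also leaves the number within the scatter. No measurement offered here accounts for these readings. Still open, going by these compounds, is whether an amine or a carboxylic acid on the sulfonyl aryl ring would move the number beyond the scatter.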